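The source may report more compounds than this note shows. Statements on the series, on what has been measured and on what is new or still open speak of the compounds shown alone.

In a functional assay on MCF7 cells (Homo sapiens) for antiproliferative activity, read by MTT assay, with a stated time of 48 h (on this read-out higher numbers stand for weaker inhibition and lower numbers for stronger inhibition), three compounds of this family have been measured so far. Compound 1 `CC(C)=CCC[C@]1(C)/C=C/[C@@H](OC(=O)C=C(C)C)[C@](C)(O)/C=C/C(=O)/C(CF)=C\C1` gives 240 nM, compound 3 `CC(C)=CCC[C@]1(C)/C=C/[C@@H](OC(=O)C=C(C)C)[C@](C)(O)/C=C/C(=O)/C(CCl)=C\C1` gives 610 nM, and compound 2 `C=C1/C=C/C(=O)/C(CO)=C\C[C@](C)(CCC=C(C)C)/C=C/[C@H]1OC(=O)C=C(C)C`, which differs from the other two in several places, gives 2750 nM. Compound 3 therefore holds the middle position of the three, with a higher number than compound 1 and a lower one than compound 2.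

Compound 4 `CC(C)=CCC[C@]1(C)/C=C/[C@@H](OC(=O)C=C(C)C)[C@](C)(O)/C=C/C(=O)/C(CN2CCN(C)CC2)=C\C1` keeps the shared core of compound 3 and changes a single group: 4-methylpiperazin-1-yl in place of chloro on a saturated chain carbon bound to a double-bonded ring carbon. In words, 4-methylpiperazin-1-yl stands in place of chloro on a saturated chain carbon bound to a double-bonded ring carbon.

Within the data shown here, only one measured step touches this place: a 2.5-fold higher number from compound 1 to compound 3 (0.41 log units; beyond the scatter), a modest change with chloro in place of fluoro. That step exchanges one halogen for another, whereas a whole ring enters in compound 4, so it is only a loose guide. Among the measured compounds shown here, no measured compound carries a ring at this place. A modest further rise in the number is expected in this assay, which would mean weaker inhibition, although the uncertainty is wide. The expected change is a 2.1-fold higher number from compound 3 to compound 4 (0.33 log units; beyond the scatter). The estimate for compound 4 is 1300 nM, with an expected range from 350 nM to 4500 nM.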

Compound 4, half-maximal inhibitory concentration: 550 nM
Compound 4: the middle estimate sits 2.4-fold (0.37 log units) above what was measured, and the stated range covers the measured number.
By their numbers in this assay, from the lowest: compound 1; then compounds 4 and 3 (each within the scatter of the next); then compound 2.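

In this assay, putting 4-methylpiperazin-1-yl in place of chloro on a saturated chain carbon bound to a double-bonded ring carbon gives a 1.1-fold lower number from compound 3 to compound 4 (0.04 log units; within the scatter). A single chlorine atom and a group of 7 heavy atoms with a six-membered non-aromatic ring therefore sit level on this read-out, so this place tolerates much more bulk than the two halogens alone could show. Fluoro still stands apart from the ring-bearing group, with a 2.3-fold higher number from compound 1 to compound 4 (0.36 log units; beyond the scatter), so the size of the group entering here does not by itself set the number: the smallest group gives the lower number against compound 4, yet the much larger group shows no difference from chloro. No measurement shown here explains why these groups compare as they do.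

On these data alone, whether the ring itself matters remains open, since a plain open-chain amine such as dimethylamino at this place would separate the effect of the nitrogen from that of the ring. A morpholine ring, with oxygen in place of the methylated nitrogen, or a carboxylic acid on the same carbon would test how far this tolerance extends.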